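Swapping isopropoxy for anilino on a shared core

A few compounds are considered here, and "the series" means these few. Any claim that something is new, unique, unknown or untested is made for them only; others in the source may bear on it.

Measured in an ADME assay on BJ cells (Homo sapiens) for cytotoxicity, read by CellTiter-Glo, with a stated time of 72 h; a lower number here means that less compound is needed, a higher number that more compound is needed for the effect:
Compound 1 `C/C1=C/C2=C[C@H](C)C[C@@]23O[C@]2(CC(C)(C)[C@@H](O)[C@@H]2C1=O)[C@@H](C)C3=O`: 10400 nM
Compound 2 `CO[C@H]1[C@@H]2C(=O)/C(C)=C\C3=C[C@H](C)C[C@@]34O[C@]2(CC1(C)C)[C@@H](C)C4=O`: 26000 nM
Compound 3 `C/C1=C/C2=C[C@H](C)C[C@@]23O[C@]2(CC(C)(C)[C@@H](OC(C)C)[C@@H]2C1=O)[C@@H](C)C3=O`: 26000 nM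

In this assay compound 3 stands at 26000 nM, level with compound 2, and together they hold the highest of the three numbers. The next compound, compound 4 `C/C1=C/C2=C[C@H](C)C[C@@]23O[C@]2(CC(C)(C)[C@@H](Nc4ccccc4)[C@@H]2C1=O)[C@@H](C)C3=O`, keeps the shared core and changes one group: anilino in place of isopropoxy on a saturated ring carbon, (anilino in place of isopropoxy on a saturated ring carbon). The closest evidence comes from changing what sits on the oxygen at that carbon. Replacing its hydrogen with methyl gave a 2.5-fold higher number from compound 1 to compound 2 (0.40 log units; beyond the scatter), and replacing it with isopropyl gave a 2.5-fold higher number from compound 1 to compound 3 (0.40 log units; beyond the scatter). Going from methyl to isopropyl gave no change at the digits printed from compound 2 to compound 3 (within the scatter). Among the compounds with values here, these steps are modest, but no measured compound carries an anilino group, so they offer only weak guidance and the direction stays open. The expected change is therefore small, a 1.3-fold lower number from compound 3 to compound 4 (0.11 log units; within the scatter), with no firm direction. For compound 4 the estimated value is 20000 nM, with an expected range of 7000 nM to 50000 nM.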

Compound 4, half-maximal effective concentration: 12600 nM
The estimate for compound 4 lay 1.6-fold (0.20 log units) above the measured number, within the range that was stated.
By their numbers in this assay, from the lowest: compounds 1 and 4 (each within the scatter of the next); then compounds 2 and 3 (each within the scatter of the next).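

In this assay, anilino on this saturated ring carbon gives a 2.1-fold lower number from compound 3 to compound 4 (0.31 log units; beyond the scatter), and replacing methoxy with it gives a 2.1-fold lower number from compound 2 to compound 4 (0.31 log units; beyond the scatter), so changing the group attached to this carbon can lower the number, whereas going from methoxy to isopropoxy left it unchanged. Replacing hydroxy with anilino gives a 1.2-fold higher number from compound 1 to compound 4 (0.08 log units; within the scatter), so the number does not simply rise with group size here: anilino has more heavy atoms than isopropoxy, yet only the two ethers stand beyond the scatter from hydroxy. Nothing available explains why the number moves with this change.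

The compounds shown do not separate the part played by the nitrogen from that of the aromatic ring. A plain amine or a cyclohexylamino group on this carbon would pull those two apart, and a chloro-substituted anilino group would test whether the ring tolerates further change.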